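The source may report more compounds than this note shows. Statements on the series, on what has been measured and on what is new or still open speak of the compounds shown alone.

Compound 1, with the structure `COc1cc(CNc2ncnc3c2ncn3C2CCCCO2)cc(OC)c1`, was tested in an ADME assay on K562 cells (Homo sapiens) for cytotoxicity, with a stated time of 72 h; on this read-out lower numbers stand for stronger inhibition and higher numbers for weaker inhibition. In this assay compound 1 gives only a limit, > 100000 nM. Compound 2, with the structure `COc1cc(CNc2ncnc3c2ncn3C2CCCCO2)cc(OC)c1OC`, differs from compound 1 by a single change, (methoxy in place of hydrogen on an aromatic carbon). In this assay compound 2 also gives only a limit, > 100000 nM. The step that the two limits leave unreadable from compound 1 to compound 2 therefore cannot be read as a number, since both ends of it are limits rather than measured values.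

Compound 3 has the structure `COc1ccc(CNc2ncnc3c2ncn3C2CCCO2)cc1`. How its core differs from the core of compound 1 is not broken down here. In this assay compound 3 gives only a limit, > 100000 nM.

Compound 4, with the structure `COc1ccc(CNc2ncnc3c2ncn3C2CCCO2)c(OC)c1`, has not yet been measured. It differs from compound 3 by methoxy in place of hydrogen on an aromatic carbon. Among the compounds with values here, this is the same kind of change as the one from compound 1 to compound 2, though its surroundings differ: in compound 2 the entering methoxy sits ortho to two methoxy groups and para to a large group, whereas in compound 4 it sits ortho to a large group and meta to a methoxy group.

Beside the unreadable step from compound 1 to compound 2, the step from compound 3 to compound 4 is expected to be a step that the limit leaves unreadable from compound 3 to compound 4, most likely again not readable as a number. That expectation rests on (the limit of > 100000 nM in this assay, at which 3 of the 3 values shown sit). Compound 4 is therefore expected to come out at about 150000 nM, somewhere between 40000 nM and 600000 nM.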

Compound 4, half-maximal inhibitory concentration: > 100000 nM
Compound 4: only a limit was reported; the forecaster's own chance of this, stated with the estimate: 85%; the middle value lies beyond the limit too.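

Compound 3 and compound 4 both give only a limit rather than a measured number, so no step can be read between them, just as none can be read between compound 1 and compound 2. The compounds shown leave open how strongly any of them acts in this assay and whether adding a methoxy group changes that at all, since all the results stop at the same point: the limit of > 100000 nM in this assay, at which 4 of the 4 values shown sit.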